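Amide nitrogen variation in an oral paw-edema series

The source may hold more compounds than are shown below. What is called first, only, known or untested is meant among the compounds shown, and "the series" means these compounds.

Measured compounds:
Compound 1 `O=C(Nc1ccc(Cl)cc1)c1c(O)c2cccnc2n(-c2ccccc2)c1=O` gives 2.5% in a functional assay on the whole organism for inhibition, with Rattus norvegicus as the target, read by cytopathic effect and paw edema, at a dose of 100 mg/kg by the oral route; a higher number here means more inhibition at the dose given (going by the name of the read-out), a lower number less inhibition.
Compound 2 `Cc1cccc(NC(=O)c2c(O)c3cccnc3n(-c3ccccc3)c2=O)c1` gives 4.5% in this assay.
Compound 3 `O=C(Nc1nccs1)c1c(O)c2cccnc2n(-c2ccccc2)c1=O` gives 2.5% in this assay.

Compound 1 stands level with compound 3 at the digits reported, and together those two are the lowest of the three numbers; compound 2 sits nearest the top, but every step among the three is within the scatter: a number 2 percentage points higher from compound 1 to compound 2 (within the scatter), no change at the digits printed from compound 1 to compound 3 (within the scatter), a number 2 percentage points lower from compound 2 to compound 3 (within the scatter). Across the set, the group on the amide-type nitrogen has been exchanged without any change in this assay beyond the scatter.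

Compound 4 `O=C(NCc1cccnc1)c1c(O)c2cccnc2n(-c2ccccc2)c1=O` differs from compound 1 by (pyridin-3-yl)methyl in place of 4-chlorophenyl on an amide-type nitrogen. The three measured steps all concern the same position, the group on the amide-type nitrogen, and all three are within the scatter, so the step to compound 4 is expected to be of the same kind: no change beyond the scatter, a number 1.5 percentage points higher from compound 1 to compound 4 (within the scatter). The estimate for compound 4 in this assay is 4%, with an expected range from 0% to 14%.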

Compound 4, a percentage reported as inhibition, in the whole organism at one dose (the size of the read-out at that dose, not a potency): 14.7%
Estimate against measurement, compound 4: 10.7 percentage points below; measured number outside the range, above it.
By their numbers in this assay, from the lowest: compounds 1, 3 and 2 (each within the scatter of the next); then compound 4.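

On the amide-type nitrogen, this assay does respond to the group carried there: (pyridin-3-yl)methyl gives a number 12.2 percentage points higher from compound 1 to compound 4 (beyond the scatter) and a number 12.2 percentage points higher from compound 3 to compound 4 (beyond the scatter) and also a number 10.2 percentage points higher from compound 2 to compound 4 (beyond the scatter) while the earlier exchanges stayed within the scatter. Against 4-chlorophenyl the heavy-atom count stays at 7 and neither group carries a net charge, so the printed differences are a ring nitrogen in place of carbon, the loss of chlorine, and one hydrogen-bond acceptor where there was none. Nothing available explains why this group stands apart from the others.

The compounds shown do not separate the carbon link to the ring from the ring nitrogen itself. Benzyl, pyridin-3-yl attached directly to the amide nitrogen, and the longer 2-(pyridin-3-yl)ethyl chain would each address part of that question.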